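This account rests on a few compounds, and the source may have more. Where it says the series, first, only, none or still open, it means among the compounds named here.

Of the compounds shown here, three that share one core have been measured in a functional assay on isolated protein for inhibition of Glucose-dependent insulinotropic receptor (Rattus norvegicus), read by HTRF and cAMP accumulation; on this read-out higher numbers stand for an effect only at larger amounts of compound and lower numbers for an effect already at smaller amounts. Compound 1 `Cc1nc(S(C)(=O)=O)ccc1Oc1ncnc(OC2CCN(C(=O)O[C@@H](C)C(F)(F)F)CC2)c1F` gives 109 nM. Compound 2 `Cc1nc(S(C)(=O)=O)ccc1Oc1ncnc(OC2CCN(C(=O)OC3(C(F)(F)F)CCC3)CC2)c1F` gives 63.3 nM, and the step of a 1.7-fold lower number from compound 1 to compound 2 (0.24 log units; within the scatter) replaces one group on the oxygen next to the carbonyl with another. Compound 3 `Cc1nc(S(C)(=O)=O)ccc1Oc1ncnc(OC2CCN(C(=O)SC(C)(C)C)CC2)c1F` gives 30.7 nM, the lowest of the three numbers; its steps of a 3.6-fold lower number from compound 1 to compound 3 (0.55 log units; beyond the scatter) and a 2.1-fold lower number from compound 2 to compound 3 (0.31 log units; beyond the scatter) both exchange the group on the carbonyl carbon, and both move the number downward by a modest amount.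

Compound 4 `Cc1nc(S(C)(=O)=O)ccc1Oc1ncnc(OC2CCN(C(=O)SC3CC3)CC2)c1F` has not yet been measured. The change from compound 3 is cyclopropyl in place of tert-butyl on a sulfur, so the sulfur that was already present is kept and only the group on it shrinks. All three measured steps bear on this position, since each alters what hangs from the carbonyl. They show that this part of the molecule moves the number by at most a modest amount, and the largest shift coincided with bringing in the sulfur, which compound 4 retains. The step from compound 3 to compound 4 is therefore expected to be small, a 1.6-fold higher number from compound 3 to compound 4 (0.21 log units; within the scatter), in this assay, leaning toward a slightly higher number. Compound 4 is estimated at 50 nM, within a range from 20 nM to 125 nM.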

Compound 4, half-maximal effective concentration: 126 nM
Beside the measured number, compound 4's estimate is 2.5-fold (0.40 log units) below it; the whole stated range lies below it.
By their numbers in this assay, from the lowest: compound 3; then compounds 2, 1 and 4 (each within the scatter of the next).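

The sulfur alone does not keep the number low: in this assay, a 4.1-fold higher number from compound 3 to compound 4 (0.61 log units; beyond the scatter) is a step beyond the scatter, so the group on the sulfur matters as well, and tert-butyl and cyclopropyl are not interchangeable here. With cyclopropyl on the sulfur, the advantage seen with tert-butyl is no longer apparent, as a 2.0-fold higher number from compound 2 to compound 4 (0.30 log units; within the scatter) and a 1.2-fold higher number from compound 1 to compound 4 (0.06 log units; within the scatter) both lie within the scatter, even though those two earlier compounds carry no sulfur on the carbonyl carbon. Nothing available here explains why these two groups on the sulfur give different numbers.

As far as these compounds go, with only tert-butyl and cyclopropyl on the sulfur, it remains open where isopropyl, cyclobutyl or a longer chain such as n-butyl would fall on this read-out. From the compounds shown here alone, it is also open whether tert-butyl would give a similar number with an oxygen in place of the sulfur, or whether a tert-butylamino group on the carbonyl carbon would do the same.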